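The source may report more compounds than this note shows. Statements on the series, on what has been measured and on what is new or still open speak of the compounds shown alone.

Of the compounds shown here, three that share one core have been measured in a functional assay on CHO cells for activation of 5-hydroxytryptamine receptor 1D (Homo sapiens), read by GTPgammaS binding; a higher number here means a larger maximal response, a lower number a smaller maximal response. Compound 1 `CN(Cc1cccs1)C1CCN(CCCc2c[nH]c3ccc(-n4cnnc4)cc23)CC1` gives 81%. Compound 2 `c1cc(CNC2CCN(CCCc3c[nH]c4ccc(-n5cnnc5)cc34)CC2)co1` gives 65%. Compound 3 `CC(=O)Nc1ccc(CNC2CCN(CCCc3c[nH]c4ccc(-n5cnnc5)cc34)CC2)cc1` gives 75%, a value that lies within the usual scatter of both compound 1 and compound 2, so no order among the three can be read from these numbers. Two steps connect them: a number 16 percentage points lower from compound 1 to compound 2 (beyond the scatter), and a number 10 percentage points higher from compound 2 to compound 3 (within the scatter). Both steps alter only the group on the amine nitrogen, and that is the same place touched in the step to compound 4 `C[C@@H](NC1CCN(CCCc2c[nH]c3ccc(-n4cnnc4)cc23)CC1)c1ccccc1`, where (1-phenylethyl in place of 4-acetamidobenzyl on an amine nitrogen). Of the measured steps, only the exchange of methyl((thiophen-2-yl)methyl)amino for ((furan-3-yl)methyl)amino moved the maximal response beyond the scatter, and the exchange of furan-3-yl for 4-acetamidophenyl stayed within it. All three numbers fall in a narrow band, so for compound 4 a step of a number 3 percentage points lower from compound 3 to compound 4 (within the scatter) is expected, meaning no change beyond the scatter. Compound 4 is estimated to reach 72%, with a likely range from 58% to 86%.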

Compound 4, largest response reached (reported as efficacy), in percent of the reference or control that the assay uses: 90%
Compound 4: the middle estimate sits 18 percentage points below what was measured; measured number above the stated range.
By their numbers in this assay, from the lowest: compounds 2, 3, 1 and 4 (each within the scatter of the next, the first and the last beyond it).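

In this assay, among these compounds, the group on the amine nitrogen can move the maximal response further than the earlier steps showed: 1-phenylethyl in place of 4-acetamidobenzyl gives a number 15 percentage points higher from compound 3 to compound 4 (beyond the scatter), and 1-phenylethyl in place of (furan-3-yl)methyl gives a number 25 percentage points higher from compound 2 to compound 4 (beyond the scatter). The gain is not seen against every group, since (1-phenylethyl)amino in place of methyl((thiophen-2-yl)methyl)amino gives a number 9 percentage points higher from compound 1 to compound 4 (within the scatter), so those two compounds cannot be told apart. Nothing available here explains these differences.

The change from 4-acetamidobenzyl to 1-phenylethyl removes the acetamido group and adds a defined stereocentre at once, so the compounds shown do not tell which of the two goes with the higher response. Plain benzyl on the same amine nitrogen would separate them, and the mirror-image 1-phenylethyl group would test the stereocentre.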